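A few compounds are considered here, and "the series" means these few. Any claim that something is new, unique, unknown or untested is made for them only; others in the source may bear on it.

Two urea compounds share one core and differ only in a single group on a fused ring. Compound 1 `O=C(Nc1ccc(-n2ncc3c(C(F)(F)F)cccc32)cc1)Nc1ccc(Cl)c(C(F)(F)F)c1` carries a trifluoromethyl there and in a functional assay on HepG2 cells (Homo sapiens) for cytotoxicity, read by MTT assay, with a stated time of 72 h (on this read-out higher numbers stand for weaker inhibition and lower numbers for stronger inhibition), compound 1 gives 8000 nM. Compound 2 `O=C(Nc1ccc(-n2ncc3c(Br)cccc32)cc1)Nc1ccc(Cl)c(C(F)(F)F)c1` carries a bromo at the same spot and in this assay compound 2 gives 2000 nM. Going by the values given here, the single measured step, a 4.0-fold lower number from compound 1 to compound 2 (0.60 log units; beyond the scatter), means compound 2 stands as the lowest of the two numbers, with compound 1 as its only neighbour.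

Compound 3 `O=C(Nc1ccc(-n2ncc3c(F)cccc32)cc1)Nc1ccc(Cl)c(C(F)(F)F)c1` takes this one step further: fluoro in place of bromo on an aromatic carbon. Among the compounds with values here, only one measured step bears on this position, the exchange of trifluoromethyl for bromo, which moved the number in this assay by a modest amount. Within the data shown here, no measured compound shows a fluoro at this spot, so nothing tells which way the new exchange will pull. The expectation is therefore a modest shift at most, with the direction open and an outcome within the scatter quite possible, that is a 2.0-fold higher number from compound 2 to compound 3 (0.30 log units; within the scatter). In this assay compound 3 is estimated at 4000 nM, expected to fall between 1500 nM and 12000 nM.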

Compound 3, half-maximal inhibitory concentration: 29500 nM
For compound 3 the middle estimate is 7.4-fold (0.87 log units) below the measured one, outside the stated range (above it).
By their numbers in this assay, from the lowest: compound 2; then compound 1; then compound 3.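

Exchanging one halogen for another on this aromatic carbon is far from a minor edit in this assay: fluoro in place of bromo gives a 15-fold higher number from compound 2 to compound 3 (1.17 log units; beyond the scatter) and counts as a large step, where the earlier exchange of trifluoromethyl for bromo was only modest. The fluoro compound also moves past the trifluoromethyl compound, with a 3.7-fold higher number from compound 1 to compound 3 (0.57 log units; beyond the scatter) in the same direction, so the number rises from bromo through trifluoromethyl to fluoro, and all three groups are separated by more than the usual scatter. Bromo and fluoro, each a single heavy atom, therefore stand at the two ends of this short series with trifluoromethyl in the middle, and nothing available here explains this order.

The three compounds leave open where a plain hydrogen, a methyl, a methoxy group, an amine or a nitrile at this spot would fall relative to bromo and fluoro. They also leave open whether the same order of groups would hold if another part of the shared core were changed.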